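Replacing pyrrolidin-1-yl with 4-methylpiperazin-1-yl

The source may report more compounds than this note shows. Statements on the series, on what has been measured and on what is new or still open speak of the compounds shown alone.

Of the compounds shown here, two with a shared core have been measured so far in an ADME assay on L6 cells (Rattus norvegicus) for cytotoxicity, read by resazurin assay, with a stated time of 72 h; on this read-out higher numbers stand for weaker inhibition and lower numbers for stronger inhibition. Compound 1 `CCN(CC)CCC(=O)N1CC2C(c3ccccc3)CC(N(C)C)(CC2c2ccccc2)C1` gives 15400 nM, while compound 2 `CN(C)C12CC(c3ccccc3)C(CN(CCN3CCCC3)C1)C(c1ccccc1)C2` gives 5580 nM, the lower of the two numbers. The next compound, compound 3 `CN1CCN(CCN2CC3C(c4ccccc4)CC(N(C)C)(CC3c3ccccc3)C2)CC1`, keeps the shared core and differs from compound 2 in one group: 4-methylpiperazin-1-yl in place of pyrrolidin-1-yl on a saturated chain carbon, two bonds along the chain from an amine nitrogen in a ring.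

Within the data shown here, only one measured step bears on this change, and only loosely. It is a 2.8-fold lower number from compound 1 to compound 2 (0.44 log units; beyond the scatter), a modest shift. That step also brought in the pyrrolidin-1-yl group, but what left was a different group, (2-(diethylamino)ethyl)carbonyl. Among the measured compounds shown here, no measurement yet shows what replacing pyrrolidin-1-yl does by itself. A single modest step is thin evidence, so only a small change is expected here, with a slight lean towards a higher number. The estimated change is a 1.4-fold higher number from compound 2 to compound 3 (0.16 log units; within the scatter), which means no step beyond the scatter is expected. For compound 3 the estimated value is 8000 nM, with an expected range from 3000 nM to 22000 nM.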

Compound 3, half-maximal inhibitory concentration: 5260 nM
Compound 3: the middle estimate sits 1.5-fold (0.18 log units) above what was measured, and the stated range covers the measured number.
By their numbers in this assay, from the lowest: compounds 3 and 2 (each within the scatter of the next); then compound 1.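

In this assay the direct exchange of pyrrolidin-1-yl for 4-methylpiperazin-1-yl gives a 1.1-fold lower number from compound 2 to compound 3 (0.03 log units; within the scatter) and so shows no real difference: on this saturated chain carbon, a six-membered ring with 2 hetero atoms does the same as a five-membered ring with 1 hetero atom. The longer step gives a 2.9-fold lower number from compound 1 to compound 3 (0.47 log units; beyond the scatter) and is beyond the scatter, as was the earlier step to compound 2, so both ring-ended chains now stand apart from compound 1 in the same direction, while the choice between these two rings leaves the number unchanged within the scatter. The data shown offer no independent measurement that could explain this result.

Each step away from compound 1 changes the carbonyl and the diethylamino end together, so it remains open which of the two accounts for the shift, and a plain 2-(diethylamino)ethyl group on the same ring nitrogen would separate them. Also open, going by these compounds, is whether a morpholin-4-yl group, which has an oxygen in the ring, or a longer chain carrying the same rings would stay within the scatter of compound 2 and compound 3.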